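Swapping the Sulfonyl Aryl Group: Expected Microsomal Half-Life

The compounds below may be only part of what the source reports. "The series", "measured", "known", "first", "only" and "open" are said of these compounds alone.

For the measured compounds named here, compound 1 `O=C(NCc1ccc(F)cc1)c1ccc(N2CCN(S(=O)(=O)c3cccnc3C3CC3)CC2)nn1` gives 0.1 h in an ADME assay on microsomes from liver (Mus musculus) for metabolic stability, read by LC-MS, using NADPH, tested at 10 uM (a higher number here means that the compound lasts longer, a lower number that the compound disappears faster), the higher of the two numbers so far. Compound 2 `O=C(NCc1ccccc1)c1ccc(N2CCN(S(=O)(=O)c3ccccc3Cl)CC2)nn1` gives 0.0333 h in this assay, and the gap between these two values lies beyond the usual scatter. Compound 3 `Cc1cc(F)ccc1S(=O)(=O)N1CCN(c2ccc(C(=O)NCc3ccc(F)cc3)nn2)CC1` differs from compound 1 in one place: 4-fluoro-2-methylphenyl in place of 2-cyclopropylpyridin-3-yl on a sulfonyl sulfur. Going by the values given here, no step between measured compounds matches this change, so the expectation rests only on both measured values sitting low. The expected step is a 1.7-fold lower number from compound 1 to compound 3 (0.22 log units; within the scatter), modest and downward, near the edge of the scatter. Compound 3 is therefore estimated at 0.06 h, within 0.02 h to 0.18 h.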

Compound 3, half-life: 0.25 h
Beside the measured number, compound 3's estimate is 4.2-fold (0.62 log units) below it, and the stated range ends below it.
By their numbers in this assay, from the lowest: compound 2; then compound 1; then compound 3.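

On a sulfonyl sulfur, 4-fluoro-2-methylphenyl in place of 2-cyclopropylpyridin-3-yl gives a 2.5-fold higher number from compound 1 to compound 3 (0.40 log units; beyond the scatter) in this assay. For the compounds shown here, this is the first single-place step, and it shows that a change at this position alone can shift the half-life beyond the usual scatter, here upward. Nothing given here bears on the reason for this step.

As far as these compounds go, it remains open whether the fluorine or the methyl of 4-fluoro-2-methylphenyl carries the step. From the compounds shown here alone, how a phenyl bearing a nitrile or a trifluoromethyl would behave on the same sulfonyl sulfur also remains open.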